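Replacing a pyrimidine amide with a plain anilide

The source may report more compounds than this note shows. Statements on the series, on what has been measured and on what is new or still open speak of the compounds shown alone.

Three amides built on one shared core have been measured in an in vitro functional assay on HEK ts201 cells for antagonist activity at Neuronal acetylcholine receptor; alpha3/beta4 (Homo sapiens), read by fluorescence and calcium flux; a lower number here means a stronger inhibitor, a higher number a weaker inhibitor. Compound 1 `O=C(NCc1ccccc1)c1ccccc1-c1ccccc1` gives 7600 nM. Compound 2 `O=C(Nc1ccccn1)c1ccccc1-c1ccccc1` gives 17500 nM, and compound 3 `O=C(Nc1ccncn1)c1ccccc1-c1ccccc1` gives 39600 nM. Compound 3 therefore stands at the weak end of this small group: the step of a 5.2-fold higher number from compound 1 to compound 3 (0.72 log units; beyond the scatter) and the step of a 2.3-fold higher number from compound 2 to compound 3 (0.35 log units; beyond the scatter) both run toward weaker inhibition, and each is beyond the scatter.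

Compound 4 `O=C(Nc1ccccc1)c1ccccc1-c1ccccc1` is the next compound to be tested. Its difference from compound 3 is phenyl in place of pyrimidin-4-yl on an amide-type nitrogen. Within the data shown here, no measured pair shows exactly this swap, but the steps along the series point the same way: a 2.3-fold higher number from compound 1 to compound 2 (0.36 log units; beyond the scatter) and a 2.3-fold higher number from compound 2 to compound 3 (0.35 log units; beyond the scatter) both show that an amide attached to a ring carrying ring heteroatoms gave a higher number than one with fewer or none. Going from compound 3 to compound 4 reverses that direction, so a move toward a lower number, beyond the scatter, is expected, on the order of a 4.4-fold lower number from compound 3 to compound 4 (0.64 log units; beyond the scatter).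

Compound 4 is thus estimated to give 9000 nM in this assay, with a plausible range from 3000 nM to 25000 nM.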

Compound 4, half-maximal inhibitory concentration: 10700 nM
The estimate for compound 4 lay 1.2-fold (0.08 log units) below the measured number; the range from low to high includes it.
By their numbers in this assay, from the lowest: compounds 1, 4 and 2 (each within the scatter of the next, the first and the last beyond it); then compound 3.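

Swapping pyrimidin-4-yl for phenyl on the amide nitrogen gives a 3.7-fold lower number from compound 3 to compound 4 (0.57 log units; beyond the scatter) in this assay, the first direct evidence that a carbon-only ring here restores most of the gap separating compound 3 from the other amides. The other two new comparisons change the picture of a steady climb with each added ring nitrogen: a 1.6-fold lower number from compound 2 to compound 4 (0.21 log units; within the scatter) and a 1.4-fold higher number from compound 1 to compound 4 (0.15 log units; within the scatter) are both within the scatter, so phenyl cannot be told apart from either pyridin-2-yl or benzyl, even though compound 1 and compound 2 do differ beyond the scatter. Compound 3 is now the weakest of the four by steps beyond the scatter to every other compound, but nothing measured here gives a reason for that.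

Still open, going by these compounds, is how a substituent on the phenyl ring of compound 4, such as a fluorine, a methoxy group, an amine or a carboxylic acid, would shift the number. Among these compounds, also open is whether a longer chain than the one in the benzyl group of compound 1 would keep this level of inhibition.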